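Butyl in place of methoxy: working notes on compound 3

This account rests on a few compounds, and the source may have more. Where it says the series, first, only, none or still open, it means among the compounds named here.

compound 1 `O=C(NO)c1cnc(N2C[C@@H]3[C@H](C2)[C@H]3NCc2ccc(F)cc2)nc1`: 380 nM
compound 2 `COc1ccc(CN[C@H]2[C@@H]3CN(c4ncc(C(=O)NO)cn4)C[C@@H]32)cc1`: 190 nM

Both values come from a functional assay on HCT-116 cells (Homo sapiens) for antiproliferative activity, read by WST assay, with a stated time of 72 h; on this read-out higher numbers stand for weaker inhibition of growth and lower numbers for stronger inhibition of growth. Going by the values given here, compound 2 stands within the scatter of compound 1, its only measured neighbour, so the two cannot be separated on these numbers. The next structure is compound 3 `CCCCc1ccc(CN[C@H]2[C@@H]3CN(c4ncc(C(=O)NO)cn4)C[C@@H]32)cc1`, which keeps the shared core and changes one group: butyl in place of methoxy on an aromatic carbon. Among the compounds with values here, in words, this is butyl in place of methoxy on an aromatic carbon, the same place that carries the only measured change.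

That change is a 2.0-fold lower number from compound 1 to compound 2 (0.30 log units; within the scatter), with methoxy in place of fluoro, and it stays within the scatter. Within the data shown here, a single small step is thin evidence, and no compound with butyl at this place has been measured in this assay. No step beyond the scatter is therefore expected, no direction is favoured, and the range has to stay wide. The estimated step is a 1.1-fold lower number from compound 2 to compound 3 (0.05 log units; within the scatter). The expected value for compound 3 is 170 nM, with an estimated range from 60 nM to 500 nM.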

Compound 3, concentration for 50% growth inhibition: 410 nM
Beside the measured number, compound 3's estimate is 2.4-fold (0.38 log units) below it, and the stated range covers the measured number.
By their numbers in this assay, from the lowest: compounds 2, 1 and 3 (each within the scatter of the next, the first and the last beyond it).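

In this assay, this position gives its first step beyond the scatter: a 2.2-fold higher number from compound 2 to compound 3 (0.33 log units; beyond the scatter) marks a modest change when butyl replaces methoxy on the aromatic carbon. Butyl and fluoro, however, cannot be separated at this place, with a 1.1-fold higher number from compound 1 to compound 3 (0.03 log units; within the scatter) showing no readable change, so the three groups do not fall into a simple order that follows the number of heavy atoms in the group, and the one readable difference is specific to the pair methoxy and butyl. No measurement on these compounds speaks to what lies behind this modest step, which therefore stands as a description only.

The compounds shown leave open whether the difference between compound 2 and compound 3 follows from the oxygen of methoxy or from the length of the butyl chain, a question that an ethoxy or a propyl group at the same place could help to separate. They also leave open how a carboxylic acid, an amine or a chain longer than butyl would behave on this aromatic carbon, and whether any such group would move the number further from the values seen so far.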